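From benzylamino to cyclopropylamino: a step behind a limit

The compounds below may be only part of what the source reports. "The series", "measured", "known", "first", "only" and "open" are said of these compounds alone.

Measured in an ADME assay on CCRF-HSB-2 cells (Homo sapiens) for cytotoxicity, with a stated time of 7 days (on this read-out higher numbers stand for lower toxicity in this test and lower numbers for higher toxicity in this test), so far:
- Compound 1 `Nc1nc(OCc2ccccc2)c2ncn(/C=C3/CC3(CO)CO)c2n1` gives > 20000 nM (a limit)
- Compound 2 `CCCSc1nc(N)nc2c1ncn2/C=C1/CC1(CO)CO` gives 98000 nM (a number)
- Compound 3 `Nc1nc(NCc2ccccc2)c2ncn(/C=C3/CC3(CO)CO)c2n1` gives > 20000 nM (a limit)

Compound 3 stands only at a limit, > 20000 nM and no number. It sits at the limit of > 20000 nM in this assay, at which 2 of the 3 values shown sit, and so has no exact place on the scale.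

Compound 4 `Nc1nc(NC2CC2)c2ncn(/C=C3/CC3(CO)CO)c2n1` changes one group of compound 3 (cyclopropyl in place of benzyl on a nitrogen on an aromatic ring) with cyclopropyl in place of benzyl on a nitrogen on an aromatic ring. The measured steps that bear on this are exchanges on an aromatic carbon, not on that nitrogen. They are a step that the two limits leave unreadable from compound 1 to compound 3 and a step that the limit leaves unreadable from compound 2 to compound 3 and lastly a step that the limit leaves unreadable from compound 1 to compound 2 (none with a readable size).

No size can therefore be carried over to the new change, and no direction in this assay is secured. Within the data shown here, compound 2 reads 98000 nM (the only true number), so low toxicity is the expected outcome for compound 4 too. The result for compound 4 may quite possibly be reported again as a limit. For compound 4 the expected move is a step that the limit leaves unreadable from compound 3 to compound 4 and it stays a loose estimate. For compound 4 the estimated value is 60000 nM with an expected range from 15000 nM to 150000 nM (a wide one).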

Compound 4, half-maximal cytotoxic concentration: > 20000 nM
Compound 4: a limit, no number; the forecaster's own chance of this, stated with the estimate: 55%; the middle value does not contradict the limit.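

In this assay compound 4 gives > 20000 nM as a limit, not a number. Among these compounds, no step from compound 1, compound 2 or compound 3 to compound 4 can be read, because the comparison rests on a limit: the limit of > 20000 nM in this assay, at which 3 of the 4 values shown sit. The compounds shown leave open how large the exchange of benzylamino for cyclopropylamino is, and in which direction it runs.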